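Bromo on the indole of compound 1: expected effect

The source may report more compounds than this note shows. Statements on the series, on what has been measured and on what is new or still open speak of the compounds shown alone.

Compound 1 `Cc1ccc(CS(=O)(=O)/C(=C/c2c[nH]c3ccccc23)C(=O)c2ccc(Cl)cc2)cc1` was tested in a functional assay on DU-145 cells (Homo sapiens) for inhibition, read by trypan blue exclusion, with a stated time of 96 h (on this read-out lower numbers stand for stronger inhibition of growth and higher numbers for weaker inhibition of growth), where compound 1 gives 25000 nM. Compound 2 `COc1ccc(/C=C(/Sc2ccc(Br)cc2)C(=O)c2ccc(Br)cc2)cc1` gives 25000 nM, level with compound 1 at the digits shown, and together the two carry the highest numbers of the three. Compound 3 `O=C(/C(=C\c1ccc([N+](=O)[O-])c(O)c1)SCc1ccc(Br)cc1)c1c(F)c(F)c(F)c(F)c1F` gives 10000 nM, the lowest of the set, with a gap to compound 1 beyond the scatter. Compound 4 `Cc1ccc(CS(=O)(=O)/C(=C/c2c[nH]c3ccc(Br)cc23)C(=O)c2ccc(Cl)cc2)cc1` is not yet measured. It differs from compound 1 in one place: bromo in place of hydrogen on an aromatic carbon. For the measured compounds named here, no measured pair differing by this change exists, so there is no measured step to lean on. The expected step of a 1.3-fold lower number from compound 1 to compound 4 (0.10 log units; within the scatter) is within the scatter, with a slight lean toward a lower number. Compound 4 is estimated at 20000 nM, with a range from 7000 nM to 50000 nM.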

Compound 4, concentration for 50% growth inhibition: 10000 nM
Beside the measured number, compound 4's estimate is 2.0-fold (0.30 log units) above it; low and high end bracket the measured number.
By their numbers in this assay, from the lowest: compounds 3 and 4 (each within the scatter of the next); then compounds 1 and 2 (each within the scatter of the next).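

Bromo in place of hydrogen on this aromatic carbon, 1H-indol-3-yl to 5-bromo-1H-indol-3-yl, gives in this assay a 2.5-fold lower number from compound 1 to compound 4 (0.40 log units; beyond the scatter) on the shared core. For the compounds shown here, this is the first one-place step, and it shows that the number responds to substitution at this position, though only modestly. No measured evidence accounts for the step.

Open: whether an amine or a carboxylic acid on the same carbon would shift the number in the same direction, and whether bromo elsewhere on this ring would give a similar step.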